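The source may report more compounds than this note shows. Statements on the series, on what has been measured and on what is new or still open speak of the compounds shown alone.

Working notes on the series. Compound 3 `O=C(/C(=C\c1c(-c2ccccc2)[nH]c2ccccc12)S(=O)(=O)c1ccccc1)c1ccccc1` gives 9900 nM in a functional assay on SR cells (Homo sapiens) for inhibition, read by sulforhodamine B assay, with a stated time of 48 h (a higher number here means a weaker inhibitor of growth, a lower number a stronger inhibitor of growth), the higher of the two numbers available there. Compound 1 `COc1ccc(-c2[nH]c3ccccc3c2/C=C(\C#N)S(=O)(=O)c2ccccc2)cc1` gives 350 nM in this assay, and the gap between the two lies beyond the scatter. Compound 2 `CC(=O)/C(=C\c1c(-c2ccccc2)[nH]c2ccccc12)S(=O)(=O)c1ccccc1` has "not determined" (no result reported) in this assay. Compound 4 `N#C/C(=C\c1c(-c2ccccc2)[nH]c2ccccc12)S(=O)(=O)c1ccccc1` is not yet measured; from compound 3 it differs by cyano in place of benzoyl on a double-bonded chain carbon bound to a double-bonded chain carbon and a sulfonyl sulfur. Compound 4 thus carries the cyano of compound 1 on the core of compound 3. A step of a 14-fold lower number from compound 3 to compound 4 (1.15 log units; beyond the scatter) toward a lower number is expected because compound 1 gives 350 nM with cyano on the double-bonded chain carbon bound to the sulfonyl sulfur. Compound 4 is estimated at 700 nM, with a range from 150 nM to 3500 nM.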

Compound 4, concentration for 50% growth inhibition: 17300 nM
Beside the measured number, compound 4's estimate is 25-fold (1.39 log units) below it, outside the stated range (above it).
By their numbers in this assay, from the lowest: compound 1; then compounds 3 and 4 (each within the scatter of the next).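

In this assay, cyano in place of benzoyl on a double-bonded chain carbon bound to a double-bonded chain carbon and a sulfonyl sulfur gives a 1.7-fold higher number from compound 3 to compound 4 (0.24 log units; within the scatter) on this core, so the two groups are not separated here. Hydrogen in place of methoxy on an aromatic carbon gives a 49-fold higher number from compound 1 to compound 4 (1.69 log units; beyond the scatter) and is the only change in the series with a step beyond the scatter. No evidence on the cause of either step is available. As far as these compounds go, whether methoxy gives a similar step with benzoyl on the chain remains open, as does the effect of an amine or a fluorine on that aromatic carbon.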